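Aryl swap on the amine-bound chain carbon: compound 4

A few compounds are considered here, and "the series" means these few. Any claim that something is new, unique, unknown or untested is made for them only; others in the source may bear on it.

The series shares one core, seen in compound 1 `O=S(=O)(NCCCNCc1cccc2ccccc12)c1cc(C(F)(F)F)cc(C(F)(F)F)c1`, which in a functional assay on Capan-2 cells (Homo sapiens) for inhibition, read by MTT assay, with a stated time of 72 h (on this read-out lower numbers stand for stronger inhibition of growth and higher numbers for weaker inhibition of growth), gives 2700 nM. Compound 2 `O=S(=O)(NCCNCc1ccc(-c2ccccc2)cc1)c1cc(C(F)(F)F)cc(C(F)(F)F)c1` gives 2400 nM in this assay. Compound 3 `O=S(=O)(NCCCNCC1COc2ccccc2O1)c1cc(C(F)(F)F)cc(C(F)(F)F)c1` gives 2500 nM in this assay. Among these three numbers compound 3 stands second highest, but its gaps to compound 2 and to compound 1 both lie within the scatter, so no order among the three can be read.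

Compound 4 `O=S(=O)(NCCCNCc1ccc(Br)cc1)c1cc(C(F)(F)F)cc(C(F)(F)F)c1` is not yet measured. It differs from compound 3 as follows: 4-bromophenyl in place of 2,3-dihydro-1,4-benzodioxin-2-yl on a saturated chain carbon bound to an amine nitrogen. Within the data shown here, the single measured step at the same place, a 1.1-fold lower number from compound 1 to compound 3 (0.03 log units; within the scatter), left the number within the scatter when one aryl group was exchanged for another on that carbon. Compound 2 carries a different chain as well as a different group, so it is not a one-point comparison and adds nothing further. Among the measured compounds shown here, with the three measured numbers close together and the only step at this position flat, no step beyond the scatter is expected in either direction, and the expected step is no change at the digits printed from compound 3 to compound 4 (within the scatter). For compound 4 the estimate in this assay is 2500 nM, expected to fall between 1200 nM and 5200 nM.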

Compound 4, concentration for 50% growth inhibition: 2000 nM
Compound 4: middle estimate off by 1.3-fold (0.10 log units), on the high side; measured number inside the range.
By their numbers in this assay, from the lowest: compounds 4, 2, 3 and 1 (each within the scatter of the next).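

In this assay, the saturated chain carbon bound to an amine nitrogen now has three measured groups, and neither new step leaves the scatter (a 1.3-fold lower number from compound 3 to compound 4 (0.10 log units; within the scatter); a 1.4-fold lower number from compound 1 to compound 4 (0.13 log units; within the scatter)). Among these compounds, until now, this position rested on the single exchange of naphthalen-1-yl for 2,3-dihydro-1,4-benzodioxin-2-yl. The result adds a different kind of change: the non-aromatic ring and the hydrogen-bond acceptors of 2,3-dihydro-1,4-benzodioxin-2-yl leave, bromine enters on a single aromatic ring of carbon only, and the number still stays within the scatter, so among compounds 1, 3 and 4 the identity of this group cannot be tied to any difference in growth inhibition, and no measured evidence on these compounds offers an explanation for that.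

As far as these compounds go, whether a carboxylic acid or an amine in place of the bromine of compound 4 would carry the number beyond the scatter remains open. From the compounds shown here alone, the effect of chain length also remains open, since compound 2 differs from the others in both chain and aryl group, and a longer chain than that of compound 4, with 4-bromobenzyl kept in place, would be needed to read it.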